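The source may hold more compounds than are shown below. What is called first, only, known or untested is meant among the compounds shown, and "the series" means these compounds.

Notes on the series so far. Of the compounds shown here, three have been read in a functional assay on MDA-MB-231 cells (Homo sapiens), read by fluorescence and BrdU incorporation, with a stated time of 48 h, tested at 25 uM; on this read-out lower numbers stand for a stronger effect and higher numbers for a weaker effect at the one concentration tested. Compound 1 `COc1cc(O)c(C(=O)/C=C/c2ccc(F)cc2)c(OC)c1` is reported in this assay as "not active" (no number reported), without a number. Compound 2 `COc1cc(OC)c(C(=O)/C=C/c2ccc(Cl)cc2)c(OC)c1` gives in this assay 2.1%, while compound 3 `COc1cccc(/C=C/C(=O)c2c(O)cc(OC)cc2OC)c1` gives 38%. Of the two numbers, compound 2 stands lowest; its nearest neighbour, compound 3, lies higher by a margin beyond the usual scatter, and compound 1 adds only an entry without a single number. Among the compounds with values here, no two measured compounds differ in one place alone, so no step between measured compounds is available.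

Compound 4 `COc1cc(OC)c(C(=O)/C=C/c2ccccc2SC)c(OC)c1` has not yet been measured in this assay. It departs from compound 2 as follows: 2-(methylsulfanyl)phenyl in place of 4-chlorophenyl on a double-bonded chain carbon bound to a double-bonded chain carbon. The remainder of the molecule, the shared core with its three methoxy groups, is kept as in compound 2.

Within the data shown here, with no measured step of this kind on hand, the direction in this assay cannot be read from the data; compound 2 and compound 3 merely show that entries can lie far apart. The step from compound 2 to compound 4 is expected as a number 17.9 percentage points higher from compound 2 to compound 4 (beyond the scatter), toward a weaker effect and likely beyond the scatter, though with wide uncertainty. Compound 4 is estimated at 20%, with a range from 3% to 55%.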

Compound 4, a percentage reported as activity, at one concentration (the size of the read-out at that concentration, not a potency): 16%
The estimate for compound 4 lay 4 percentage points above the measured number, and the stated range covers the measured number.
By their numbers in this assay, from the lowest: compound 2; then compound 4; then compound 3.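

Within the data shown here, exchanging 4-chlorophenyl for 2-(methylsulfanyl)phenyl on a double-bonded chain carbon bound to a double-bonded chain carbon gives, in this assay, a number 13.9 percentage points higher from compound 2 to compound 4 (beyond the scatter), which is the first measured sign that this place responds to a change of its group, here toward a weaker effect. The response has a limited size in this one case: with the shared core and its three methoxy groups kept, compound 4 gives 16%, which remains on the lower side of the numbers seen so far. The change alters the substituent and its printed ring position in a single step, and nothing measured bears on why the number moves, so the step stands as an observation only.

Still open, on these data alone, is how much of the step belongs to the loss of chlorine, to the arrival of methylsulfanyl, or to the different ring position, a question that a plain phenyl or a 4-(methylsulfanyl)phenyl at this place would help to separate. Also open, as far as these compounds go, is how an amine or a carboxylic acid on this phenyl would read with the same core.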